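The source may hold more compounds than are shown below. What is called first, only, known or untested is meant among the compounds shown, and "the series" means these compounds.

In a functional assay on MCF7 cells (Homo sapiens) for inhibition, read by MTT assay, with a stated time of 72 h (on this read-out lower numbers stand for stronger inhibition and higher numbers for weaker inhibition), two compounds have been measured so far. Compound 1 (`COc1cc(NC(C)CCCNC(=O)Nc2cccc(F)c2)c2ncccc2c1`) gives 18000 nM, and compound 2 (`COc1cc(NC(C)CCCNC(=O)Nc2ccc(Br)cc2)c2ncccc2c1`) gives 2600 nM, the lower of the two numbers.

The next compound is compound 3 (`COc1cc(NC(C)CCCNC(=O)NNC(=O)Nc2ccc(F)cc2)c2ncccc2c1`). Its change from compound 2 is ((4-fluorophenyl)carbamoyl)amino in place of 4-bromophenyl on an amide-type nitrogen.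

Among the measured compounds shown here, only one measured step bears on this change. a 6.9-fold lower number from compound 1 to compound 2 (0.84 log units; beyond the scatter) comes with 4-bromophenyl in place of 3-fluorophenyl on an amide-type nitrogen. That step shows that a change on this nitrogen can move the number in this assay beyond the scatter, but it is a smaller exchange than the one now at hand. For the measured compounds named here, no measured compound carries the entering group, so the data give no direction for this step. The central expectation is therefore no shift beyond the scatter, with a wide margin on both sides, about as large as the step from compound 1 or larger.

The expected change is a 1.3-fold lower number from compound 2 to compound 3 (0.11 log units; within the scatter). For compound 3, the estimated value is 2000 nM, with an expected range of 300 nM to 13000 nM.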

Compound 3, half-maximal inhibitory concentration: 310 nM
Compound 3: middle estimate off by 6.5-fold (0.81 log units), on the high side; the range from low to high includes it.
By their numbers in this assay, from the lowest: compound 3; then compound 2; then compound 1.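

In this assay, the change on this amide-type nitrogen now has a direction: ((4-fluorophenyl)carbamoyl)amino in place of 4-bromophenyl gives an 8.4-fold lower number from compound 2 to compound 3 (0.92 log units; beyond the scatter), so the entering group, with its 11 heavy atoms against 7 and its added hydrogen-bond donors and acceptor, goes with a lower number rather than a higher one. Among the compounds shown here, measured against 3-fluorophenyl, the same group gives a 58-fold lower number from compound 1 to compound 3 (1.76 log units; beyond the scatter), the largest step so far, and compound 3 stands lowest, with both of its steps beyond the scatter. Nothing measured here accounts for these steps.

The compounds shown do not separate the extended carbamoyl-amino unit from the exchange of bromine for fluorine on the phenyl ring; 4-fluorophenyl placed directly on this nitrogen, or ((4-bromophenyl)carbamoyl)amino, would divide the two contributions. Also open, going by these compounds, is how the number responds to a longer chain within the entering group, or to an amine or a carboxylic acid on its phenyl ring.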